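Dichlorophenyl for dichlorothiophenyl on the imine carbon

The compounds below may be only part of what the source reports. "The series", "measured", "known", "first", "only" and "open" are said of these compounds alone.

In a functional assay on RAW264.7 cells (Mus musculus) for cytotoxicity, read by MTT assay, with a stated time of 48 h, tested at 50 uM (a lower number here means a weaker effect, a higher number a stronger effect of the compound at the concentration tested), compound 1 `CS(=O)(=O)c1ccc(Cc2nnc3n2N=C(c2ccccc2)CS3)cc1` gives 46.7%, and compound 2 `CS(=O)(=O)c1ccc(Cc2nnc3n2N=C(c2cc(Cl)sc2Cl)CS3)cc1` gives 25.5%, the lowest of the two numbers in hand. Among the compounds with values here, the only measured step, a number 21.2 percentage points lower from compound 1 to compound 2 (beyond the scatter), went with 2,5-dichlorothiophen-3-yl in place of phenyl. Compound 3 `CS(=O)(=O)c1ccc(Cc2nnc3n2N=C(c2ccc(Cl)cc2Cl)CS3)cc1` differs from compound 2 by 2,4-dichlorophenyl in place of 2,5-dichlorothiophen-3-yl on a carbon with a double bond to nitrogen. Within the data shown here, no measured step covers this exchange; the one step available argues only that changing this aryl group can move the read-out by a modest amount. Among the measured compounds shown here, compound 3 is therefore expected to land between the two known numbers, at 35% with a range of 15% to 55%. The expected step is a number 9.5 percentage points higher from compound 2 to compound 3 (within the scatter).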

Compound 3, a percentage reported as activity, at one concentration (the size of the read-out at that concentration, not a potency): 27.3%
Compound 3: middle estimate off by 7.7 percentage points, on the high side; the range from low to high includes it.
By their numbers in this assay, from the lowest: compounds 2 and 3 (each within the scatter of the next); then compound 1.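

In this assay, 2,4-dichlorophenyl in place of 2,5-dichlorothiophen-3-yl on the carbon with a double bond to nitrogen gives a number 1.8 percentage points higher from compound 2 to compound 3 (within the scatter) and so leaves the read-out unresolved between these two dichlorinated aryl groups. Against phenyl, the same group gives a number 19.4 percentage points lower from compound 1 to compound 3 (beyond the scatter) in the same direction as the step from phenyl to the dichlorothiophene. Nothing available gives a cause for either step. Open, on these data alone, is how a phenyl carrying a single chlorine, a methoxy group or an amine would read at this position.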